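A few compounds are considered here, and "the series" means these few. Any claim that something is new, unique, unknown or untested is made for them only; others in the source may bear on it.

Series notes. The shared core carries a hydrazone on one side and a trifluoromethyl group on the other; the compounds differ in the aryl group on the core and in the substituent on the benzylidene ring. Compound 1 `Nc1c(C(=O)N/N=C/c2ccc(Br)cc2)oc2nc(-c3cccs3)cc(C(F)(F)F)c12` gives in an ADME assay on HEK293 cells (Homo sapiens) for antiproliferative activity, read by MTT assay (on this read-out lower numbers stand for stronger inhibition and higher numbers for weaker inhibition), a value of 86000 nM. Compound 2 `Nc1c(C(=O)N/N=C/c2ccc(Cl)cc2)oc2nc(-c3cccs3)cc(C(F)(F)F)c12` gives 83000 nM. Compound 3 `Cc1ccc(/C=N/NC(=O)c2oc3nc(-c4ccccc4)cc(C(F)(F)F)c3c2N)cc1` gives 69000 nM. Going by the values given here, the only single-point step among the measured compounds is a 1.0-fold lower number from compound 1 to compound 2 (0.02 log units; within the scatter). Compound 3 sits within the scatter of both compound 2 and compound 1, so the three numbers are not separated from one another.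

Compound 4 `Cc1ccc(/C=N/NC(=O)c2oc3nc(-c4cccs4)cc(C(F)(F)F)c3c2N)cc1` is not yet measured. It differs from compound 3 in one place: thiophen-2-yl in place of phenyl on an aromatic carbon. Among the compounds with values here, no measured pair isolates this exchange: compounds 1 and 2 already carry the thiophen-2-yl group, but they also differ from compound 3 on the benzylidene ring, and the bromo-to-chloro step says nothing about the aryl group on the core. What the three numbers show is that neither aryl group nor benzylidene substituent moved the read-out beyond the scatter. On that basis, no step beyond the scatter is expected from compound 3 to compound 4 in this assay, and the expected step is a 1.1-fold higher number from compound 3 to compound 4 (0.04 log units; within the scatter). Compound 4 is therefore estimated at 75000 nM, with a range from 35000 nM to 160000 nM.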

Compound 4, half-maximal inhibitory concentration: 78000 nM
Compound 4: the middle estimate sits 1.0-fold (0.02 log units) below what was measured; low and high end bracket the measured number.
By their numbers in this assay, from the lowest: compounds 3, 4, 2 and 1 (each within the scatter of the next).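

Working notes on the series. In this assay, the exchange of phenyl for thiophen-2-yl on the aromatic carbon next to the ring nitrogen is now isolated, with the methyl group on the benzylidene ring held constant, and it stays within the scatter (a 1.1-fold higher number from compound 3 to compound 4 (0.05 log units; within the scatter)). With thiophen-2-yl held constant, the benzylidene substituent can now also be read beyond the halogen pair: methyl in place of chloro (a 1.1-fold lower number from compound 2 to compound 4 (0.03 log units; within the scatter)) and methyl in place of bromo (a 1.1-fold lower number from compound 1 to compound 4 (0.04 log units; within the scatter)) both stay within the scatter, so neither of the two single-place changes seen at these sites separates the compounds. No independent evidence on these compounds bears on why the read-out stays flat across these exchanges.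

The compounds shown leave open whether an amine or a carboxylic acid on the benzylidene ring would give a step beyond the scatter. They also leave open whether a saturated ring or a longer chain in place of the aryl group, on the same aromatic carbon, would do so, since only phenyl and thiophen-2-yl stand there.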